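An Amine Chain in Place of a Dichlorobenzyl Group

The source may report more compounds than this note shows. Statements on the series, on what has been measured and on what is new or still open speak of the compounds shown alone.

Compound 1 `Nc1nc(O)c2c(n1)n(C1OC(CO)[C@@H](O)[C@H]1O)c(=O)n2Cc1ccc(Cl)c(Cl)c1` is one of three substances examined in a functional assay on the whole organism (B cells) with Mus musculus as the target; on this read-out lower numbers stand for smaller maximal responses and higher numbers for larger maximal responses. In this assay compound 1 gives 55%, the second highest of the three numbers. Compound 2 `C=CCn1c(=O)n(C2CN(CCCC)CC(CO)O2)c2nc(N)nc(O)c21` gives 38% in this assay, a lower number that lies beyond the usual scatter of the method. Compound 3 `C=CCn1c(=O)n([C@@H]2O[C@H](CO)[C@H]3OC(CCC)(CCC)O[C@H]32)c2nc(N)nc(O)c21` reaches 123% in this assay, well above compound 1 and again beyond the scatter. Compounds 2 and 3 each differ from compound 1 in more than one place, so neither offers a single-change comparison, and only their bare values can be set beside that of compound 1.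

Compound 4 `CN(C)CCCn1c(=O)n(C2OC(CO)[C@@H](O)[C@H]2O)c2nc(N)nc(O)c21` differs from compound 1 in a single place: 2-(dimethylamino)ethyl in place of 3,4-dichlorophenyl on a saturated chain carbon bound to an aromatic nitrogen. The same difference, cut one bond further out, reads 3,4-dichlorobenzyl to 3-(dimethylamino)propyl. Among the measured compounds shown here, no measured pair shows this change, and the two other compounds carry yet another group at that place while differing elsewhere as well, so the account has no comparable step to lean on. The writer therefore expects a modest downward step a number 10 percentage points lower from compound 1 to compound 4 (within the scatter) for compound 4, one that may not clearly exceed the scatter. Compound 4 is estimated to give 45%, with a range from 20% to 80%.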

Compound 4, largest response reached (reported as maximal response), in percent of the reference or control that the assay uses: 83%
Compound 4: the middle estimate sits 38 percentage points below what was measured; the whole stated range lies below it.
By their numbers in this assay, from the lowest: compound 2; then compound 1; then compound 4; then compound 3.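

In this assay, among the compounds shown here, the exchange of 3,4-dichlorobenzyl for 3-(dimethylamino)propyl appears as a number 28 percentage points higher from compound 1 to compound 4 (beyond the scatter) and gives the first single-change comparison in this set. It shows that, at this place on a saturated chain carbon bound to an aromatic nitrogen, the 3,4-dichlorophenyl ring is not required for a maximal response of this size, as a chain with no ring and a 2-(dimethylamino)ethyl end goes with the larger number on the shared core. No measurement at hand explains the rise, and the finding rests on this one pair.

As far as these compounds go, what remains open is whether the rise goes with the incoming amine or with the departure of the 3,4-dichlorophenyl ring, a question that a plain propyl chain or an unsubstituted benzyl group at this place could help to separate. The compounds shown also leave open how the response would follow a longer chain ending in the same dimethylamino group, or a chain ending in a carboxylic acid.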